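Triazole-phthalimide series: propargyl to aryl ketone replacement

The source may report more compounds than this note shows. Statements on the series, on what has been measured and on what is new or still open speak of the compounds shown alone.

Measured so far
compound 1 `Cc1ccc(C(=O)CSc2nnc(C)n2N2C(=O)c3ccccc3C2=O)cc1` — > 200000 nM
compound 2 `C#CCSc1nnc(-c2cc(OC)c(OC)c(OC)c2)n1N1C(=O)c2ccccc2C1=O` — > 200000 nM

Compound 2 `C#CCSc1nnc(-c2cc(OC)c(OC)c(OC)c2)n1N1C(=O)c2ccccc2C1=O` gives in a functional assay on PC-3M cells (Homo sapiens) for cytotoxicity, read by MTT assay, with a stated time of 48 h (a lower number here means a stronger inhibitor, a higher number a weaker inhibitor), a value that is only a limit of the assay, > 200000 nM. The same holds for compound 1 `Cc1ccc(C(=O)CSc2nnc(C)n2N2C(=O)c3ccccc3C2=O)cc1`, which in this assay also reaches only the limit, > 200000 nM. Within the data shown here, both values shown therefore sit at the limit, as recorded in the limit of > 200000 nM in this assay, at which 2 of the 2 values shown sit, so compound 2 cannot be placed anywhere within a measured range; no step between measured compounds is available.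

Compound 3 `COc1cc(-c2nnc(SCC(=O)c3ccccc3C)n2N2C(=O)c3ccccc3C2=O)cc(OC)c1OC` is the next compound to be tested. It differs from compound 2 as (2-methylphenyl)carbonyl in place of ethynyl on a saturated chain carbon bound to a sulfur.

Among the measured compounds shown here, with no measured step to lean on and both measured compounds at the limit, the expected step of a number no higher from compound 2 to compound 3 (the limit leaves the size open) is none beyond the scatter; a limit result is expected again. Compound 3 is accordingly estimated at 200000 nM in this assay, with a range from 80000 nM to 400000 nM.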

Compound 3, half-maximal inhibitory concentration: > 200000 nM
Compound 3: no number, only a limit; the forecaster's own chance of this, stated with the estimate: 85%; the middle value lies on the limit itself.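

Compound 3 gives only a limit in this assay, > 200000 nM, and since compound 2 also stands at a limit, no step can be read between compound 2 and compound 3. All values shown sit at one limit: the limit of > 200000 nM in this assay, at which 3 of the 3 values shown sit.

The compounds shown leave open whether ((2-methylphenyl)carbonyl)methyl in place of propargyl changes the value in this assay at all.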